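A few compounds are considered here, and "the series" means these few. Any claim that something is new, unique, unknown or untested is made for them only; others in the source may bear on it.

Measured so far in an ADME assay on L6 cells (Rattus norvegicus) for cytotoxicity; a higher number here means a weaker inhibitor, a lower number a stronger inhibitor
- compound 1 `COc1ccc(S(=O)(=O)N2c3ccccc3CCC2C)cc1` gives 5990 nM
- compound 2 `CC1CCc2ccccc2N1S(=O)(=O)c1ccc([N+](=O)[O-])cc1` gives 248000 nM
- compound 3 `CC1CCc2ccccc2N1S(=O)(=O)c1cccc([N+](=O)[O-])c1` gives 187000 nM

Compound 1 holds the lowest number of the three, and both other compounds lie well beyond the scatter from it. Next is compound 4 `CC(=O)Nc1ccc(S(=O)(=O)N2c3ccccc3CCC2C)cc1`, with the change acetamido in place of methoxy on an aromatic carbon on an aromatic carbon, para to a large group. One measured step replaces the same methoxy, a 41-fold higher number from compound 1 to compound 2 (1.62 log units; beyond the scatter), which is large. Acetamido is a different group, so that single step is thin support. A step in the same direction but of smaller size is expected in this assay on the strength of it. The expected step is a 6.7-fold higher number from compound 1 to compound 4 (0.82 log units; beyond the scatter) as an estimate only. For compound 4 the estimated value is 40000 nM, with an expected range from 10000 nM to 150000 nM.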

Compound 4, half-maximal inhibitory concentration: 52000 nM
The estimate for compound 4 lay 1.3-fold (0.11 log units) below the measured number; low and high end bracket the measured number.
By their numbers in this assay, from the lowest: compound 1; then compound 4; then compounds 3 and 2 (each within the scatter of the next).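

In this assay, the aromatic carbon para to a large group now has two replacements of methoxy, and acetamido also gives a higher number (an 8.7-fold higher number from compound 1 to compound 4 (0.94 log units; beyond the scatter)). The entering group matters as well, since acetamido and nitro differ beyond the scatter at this carbon (a 4.8-fold lower number from compound 2 to compound 4 (0.68 log units; beyond the scatter)). No measurement on hand accounts for either step.

Open, on these data alone, is where an amine or a carboxylic acid at this carbon would fall relative to compound 1 and compound 4. Also open, as far as these compounds go, is whether a longer acyl chain on the amide nitrogen would move the number further from that of compound 4.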